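Swapping the benzyl linker for a bare phenyl

This account rests on a few compounds, and the source may have more. Where it says the series, first, only, none or still open, it means among the compounds named here.

Of the compounds shown here, three sharing one core have been measured so far. In a functional assay on cells for positive allosteric modulation of G-protein coupled receptor 68 (Homo sapiens), read by a luciferase reporter and cAMP accumulation, with a stated time of 30 min, at pH 6.8 and pH 8.3, in the presence of a further agent that is not named here (a lower number here means a less potent compound, a higher number a more potent compound, by a factor of ten per unit of this negative logarithm), compound 1 `Nc1nc(NCc2cccc(F)c2)nc(-c2ccccc2CO)n1` gives 4.52, compound 2 `Nc1nc(NCc2cccc(C(F)(F)F)c2)nc(-c2ccccc2CO)n1` gives 5.11, and compound 3 `COc1cccc(CNc2nc(N)nc(-c3ccccc3CO)n2)c1` gives 4.11. Compound 1 therefore stands second highest of the three: the step of a number 0.59 log units higher from compound 1 to compound 2 (beyond the scatter) lifts it, while the step of a number 0.41 log units lower from compound 1 to compound 3 (beyond the scatter) lowers it, and the longer step of a number 1.00 log units lower from compound 2 to compound 3 (beyond the scatter) spans both.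

Compound 4 `Nc1nc(Nc2ccccc2)nc(-c2ccccc2CO)n1` differs from compound 1 by phenyl in place of 3-fluorobenzyl on a nitrogen on an aromatic ring. Going by the values given here, none of the measured steps touches this spot directly; all three keep the benzyl group and change only the substituent on its ring. Those steps do show that changes on this arm shift the number in this assay by modest amounts in either direction. Removing the methylene and the fluorine together is a larger alteration, with no measured guide to its direction, so a modest downward step a number 0.22 log units lower from compound 1 to compound 4 (within the scatter) is expected with wide uncertainty. Compound 4 is estimated at 4.3, likely between 3.7 and 5.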

Compound 4, negative logarithm of the antagonist equilibrium constant: 3.92
Compound 4: the middle estimate sits 0.38 log units above what was measured; the range from low to high includes it.
By their numbers in this assay, from the lowest: compounds 4 and 3 (each within the scatter of the next); then compound 1; then compound 2.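

In this assay, going by these compounds alone, the change on the nitrogen gives a number 0.60 log units lower from compound 1 to compound 4 (beyond the scatter), the first measured step that alters the arm itself rather than a substituent on its ring. It shows that the number at this position also responds to replacing the whole 3-fluorobenzyl group, and in this one case phenyl gives the lower number. This single step changes the methylene and the fluorine together, so it cannot assign the loss to either, and no measurement available here explains it.

A plain benzyl group would keep the methylene without the fluorine, and a fluorophenyl group would keep the fluorine without the methylene, so either could help separate the two changes. A longer chain, such as phenylethyl, leaves open how the number responds when the arm is extended rather than shortened.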